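Dioxolane in place of methoxy on the ethyl chain

The compounds below may be only part of what the source reports. "The series", "measured", "known", "first", "only" and "open" are said of these compounds alone.

Compound 2 `CCN(CC)c1ccc(NC(=O)c2c(-c3c(Cl)cccc3Cl)noc2CCOC)cc1` gives 110 nM in an in vitro assay on CHO-K cells with growth hormone secretagogue receptor type 1 (Homo sapiens) as the target; on this read-out lower numbers stand for stronger inhibition and higher numbers for weaker inhibition; it stands second highest of the three numbers, nearest to compound 1 `CCN(CC)c1ccc(NC(=O)c2c(-c3c(Cl)cccc3Cl)noc2C(C)C)cc1` at 150 nM and furthest from compound 3 `CCN(CC)c1ccc(NC(=O)c2c(-c3c(Cl)cccc3Cl)noc2CCC2OCCCO2)cc1` at 6 nM. The step of a 1.4-fold lower number from compound 1 to compound 2 (0.13 log units; within the scatter) lies within the scatter, whereas an 18-fold lower number from compound 2 to compound 3 (1.26 log units; beyond the scatter) and a 25-fold lower number from compound 1 to compound 3 (1.40 log units; beyond the scatter) are large. Compound 4 `CCN(CC)c1ccc(NC(=O)c2c(-c3c(Cl)cccc3Cl)noc2CCC2OCCO2)cc1` carries the change (1,3-dioxolan-2-yl in place of methoxy on a saturated chain carbon, two bonds along the chain from an aromatic carbon). The step of an 18-fold lower number from compound 2 to compound 3 (1.26 log units; beyond the scatter) bears most directly on it, since it exchanges the same methoxy for a six-membered ring of the same kind at the same place; the five-membered ring here is expected to behave alike. The estimated step is a 9.2-fold lower number from compound 2 to compound 4 (0.96 log units; beyond the scatter), a lower number beyond the scatter. Compound 4 is therefore expected at 12 nM, within 4 nM to 40 nM.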

Compound 4, half-maximal inhibitory concentration: 25 nM
Compound 4: middle estimate off by 2.1-fold (0.32 log units), on the low side; the measured number falls inside the stated range.
By their numbers in this assay, from the lowest: compound 3; then compound 4; then compounds 2 and 1 (each within the scatter of the next).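

In this assay the gain over the open-chain groups is not confined to the six-membered ring of compound 3: 1,3-dioxolan-2-yl also improves on methoxy (a 4.4-fold lower number from compound 2 to compound 4 (0.64 log units; beyond the scatter)), and 2-(1,3-dioxolan-2-yl)ethyl improves on isopropyl (a 6.0-fold lower number from compound 1 to compound 4 (0.78 log units; beyond the scatter)). Ring size still counts at this place, as the five-membered ring gives back part of that gain (a 4.2-fold higher number from compound 3 to compound 4 (0.62 log units; beyond the scatter)). No measurement at hand accounts for the difference between the two rings.

Going by these compounds, what a cyclohexyl group with no ring oxygen would give here stays open. So does the effect of a longer chain between the core and the ring.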